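Oxan-4-ylmethyl in place of isopropyl: clearance outlook

A few compounds are considered here, and "the series" means these few. Any claim that something is new, unique, unknown or untested is made for them only; others in the source may bear on it.

The three measured compounds share one core and differ only in the aromatic group attached to it. In an ADME assay on microsomes from liver (Homo sapiens) for metabolic stability (on this read-out higher numbers stand for fast clearance and lower numbers for slow clearance), compound 1 `COc1cc(F)ccc1-c1ccnc2[nH]c(C3CCN(CC(=O)N(C)C)CC3)cc12` gives 14 uL/min. Compound 2 `CC(C)Cn1cc(-c2ccnc3[nH]c(C4CCN(CC(=O)N(C)C)CC4)cc23)ccc1=O` gives 21 uL/min in this assay. For compound 3 `CC(C)n1cc(-c2ccnc3[nH]c(C4CCN(CC(=O)N(C)C)CC4)cc23)ccc1=O` the same read-out is only a limit, < 3 uL/min, as noted in the limit of < 3 uL/min in this assay, at which 1 of the 3 values shown sits. Compound 3 thus stands at the low end of the set: the steps of an at least 4.6-fold lower number from compound 1 to compound 3 (0.66 log units; beyond the scatter) and an at least 7.0-fold lower number from compound 2 to compound 3 (0.84 log units; beyond the scatter) are both beyond the scatter.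

Compound 4 `CN(C)C(=O)CN1CCC(c2cc3c(-c4ccc(=O)n(CC5CCOCC5)c4)ccnc3[nH]2)CC1` is not yet measured. It differs from compound 3 by (oxan-4-yl)methyl in place of isopropyl on an aromatic nitrogen. Of the two measured steps, only an at least 7.0-fold lower number from compound 2 to compound 3 (0.84 log units; beyond the scatter) changes the group on this aromatic nitrogen, and there the move to the smaller group went with the lower number. Compound 4 carries a larger group at the same position, so a rise in this assay is expected, estimated as an at least 2.6-fold higher number from compound 3 to compound 4 (0.42 log units; beyond the scatter), modest in size and uncertain, since the starting point for compound 3 is only a limit. The estimated value for compound 4 is 8 uL/min, with a likely range from 3 uL/min to 20 uL/min.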

Compound 4, intrinsic clearance in a liver preparation (reported as CLH), per the amount of preparation that the assay uses: 20 uL/min
Compound 4: the middle estimate sits 2.5-fold (0.40 log units) below what was measured, within the range that was stated.
By their numbers in this assay, from the lowest: compounds 1, 4 and 2 (each within the scatter of the next). At a limit, below all of these: compound 3.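

In this assay, (oxan-4-yl)methyl in place of isopropyl on the aromatic nitrogen gives an at least 6.6-fold higher number from compound 3 to compound 4 (0.82 log units; beyond the scatter), so the low reading of compound 3 does not carry over to this larger group. Oxan-4-yl in place of isopropyl on the saturated chain carbon bound to the aromatic nitrogen gives a 1.1-fold lower number from compound 2 to compound 4 (0.02 log units; within the scatter), so the ring and its hydrogen-bond acceptor leave compound 4 within the scatter of compound 2. Among compounds 2, 3 and 4, which differ at this nitrogen, the two groups with that saturated chain carbon read alike, and only isopropyl, which lacks it, stands apart.

As far as these compounds go, the true size of the rise from compound 3 cannot be read, because compound 3 is only a limit: the limit of < 3 uL/min in this assay, at which 1 of the 4 values shown sits. It also stays open whether an ethyl, a cyclopropyl or an oxan-4-yl group on the aromatic nitrogen would read with compound 3 or with compounds 2 and 4.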